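The source may hold more compounds than are shown below. What is called first, only, known or untested is meant among the compounds shown, and "the series" means these compounds.

Series notes. In a functional assay on A-375 cells (Homo sapiens) for inhibition, read by CCK-8 assay, with a stated time of 72 h, tested at 8 uM (on this read-out higher numbers stand for more inhibition of growth at the one concentration tested and lower numbers for less inhibition of growth), compound 1 `Nc1ccccc1NC(=O)c1ccc(CSc2nccc(C(F)(F)F)n2)cc1` gives 80.1% and compound 3 `Cc1ccc(SCc2ccc(C(=O)Nc3ccccc3N)cc2)cc1` gives 67%. Compound 2 `Nc1ccccc1NC(=O)/C=C/c1ccc(CSc2ccc(F)cc2)cc1` gives 24.6% in this assay, the lowest of the three numbers; the gap to compound 3 and the gap to compound 1 both lie beyond the scatter. The unmeasured compound 4 `Nc1ccccc1NC(=O)/C=C/c1ccc(CSc2cccc3ccccc23)cc1` differs from compound 2 by naphthalen-1-yl in place of 4-fluorophenyl on a sulfur. Going by the values given here, no measured pair shows this kind of change, so the size of the step is uncertain; a modest rise is expected, a number 11.4 percentage points higher from compound 2 to compound 4 (beyond the scatter), though a step within the scatter remains possible. For compound 4 in this assay the estimate is 36%, with a range from 15% to 60%.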

Compound 4, percent growth inhibition at one concentration: 36%
For compound 4 middle estimate and measured number coincide at the digits printed; measured number inside the range.
By their numbers in this assay, from the lowest: compound 2; then compound 4; then compound 3; then compound 1.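

Working from this assay, this is the first one-place comparison in the series: at the sulfur whose other neighbour is a saturated chain carbon, naphthalen-1-yl in place of 4-fluorophenyl gives a number 11.4 percentage points higher from compound 2 to compound 4 (beyond the scatter) and so shows that this position responds to the aryl group it carries. The available data offer no explanation for the rise.

Open, as far as these compounds go, is how a carboxylic acid or an amine on this sulfur would read. Also open, from the compounds shown here alone, is whether naphthalen-1-yl would give a similar step on the core of compound 3.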